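From compound 3 to compound 4: a fluorine shift

This account rests on a few compounds, and the source may have more. Where it says the series, first, only, none or still open, it means among the compounds named here.

In an ADME assay on Vero cells (Chlorocebus sabaeus) for cytotoxicity, read by MTT assay, with a stated time of 72 h (a higher number here means that more compound is tolerated, a lower number that less compound is tolerated), compound 3 `C[C@]1(CN2CCc3nc(-c4ccc(F)c(Cl)c4)ccc3C2)Cn2cc([N+](=O)[O-])nc2O1` gives > 32 ug/mL, which is a limit of the assay. Compound 2 `C[C@]1(CN2CCc3nc(-c4ccc(C(F)(F)F)cc4)ccc3C2)Cn2cc([N+](=O)[O-])nc2O1` gives > 32 ug/mL, which is also a limit. Compound 1 `C[C@]1(CN2CCc3nc(C4CCOCC4)ccc3C2)Cn2cc([N+](=O)[O-])nc2O1` offers no help, with the entry "not determined" (no result reported). The series therefore stands at the limit of > 32 ug/mL in this assay, at which 2 of the 3 values shown sit, and no exact figure is available for compound 3.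

Compound 4 `C[C@]1(CN2CCc3nc(-c4cc(F)cc(Cl)c4)ccc3C2)Cn2cc([N+](=O)[O-])nc2O1` differs from compound 3 as follows: 3-chloro-5-fluorophenyl in place of 3-chloro-4-fluorophenyl on an aromatic carbon. Here 3-chloro-5-fluorophenyl takes the place of 3-chloro-4-fluorophenyl on the aromatic carbon next to the ring nitrogen, and the two compounds have the same atoms, joined differently.

Among the measured compounds shown here, the only measured step that bears on this change is a step that the two limits leave unreadable from compound 2 to compound 3. It involves the same aromatic carbon but gives no size to carry over. The expectation rests on compound 3, which gives > 32 ug/mL, again a limit. The expected step that the limit leaves unreadable from compound 3 to compound 4 stays within the usual scatter of this assay, with no direction foreseen. A report as a limit is also the likeliest outcome for compound 4. For compound 4 the estimated value is 40 ug/mL, with an expected range from 20 ug/mL to 64 ug/mL.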

Compound 4, half-maximal cytotoxic concentration: > 32 ug/mL
Compound 4 gave a limit, no number (the forecaster's own chance of this, stated with the estimate: 85%); the middle value does not contradict the limit.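

In this assay compound 4 gives > 32 ug/mL, which is a limit. Among the compounds shown here, the steps to compound 4 from compound 2 and from compound 3 cannot be read, so no new step follows. The compounds shown leave open where the half-maximal cytotoxic concentrations of compound 2, compound 3 and compound 4 lie, and whether these substituent changes alter them: the limit of > 32 ug/mL in this assay, at which 3 of the 4 values shown sit.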